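Aryl sulfone replaces sulfonamide in a urea series

This account rests on a few compounds, and the source may have more. Where it says the series, first, only, none or still open, it means among the compounds named here.

Compound 3 `CN(Cc1ccccc1)S(=O)(=O)c1ccc(NC(=O)NCc2ccncc2)cc1` holds the lowest of the two numbers available in an assay on isolated protein for activation of Nicotinamide phosphoribosyltransferase (Homo sapiens) (on this read-out higher numbers stand for an effect only at larger amounts of compound and lower numbers for an effect already at smaller amounts), where compound 3 gives 23 nM. Compound 2 `CCOC(=O)c1ccc(NC(=S)NCc2ccncc2)cc1` in this assay gives 9770 nM, and the gap to compound 3 lies beyond the usual scatter. Compound 1 `CCOC(=O)c1ccc(NC(=O)NCc2ccnnc2)cc1` is reported in this assay only as a limit, > 100000 nM, which is the limit of > 100000 nM in this assay, at which 1 of the 3 values shown sits. Compound 4 `O=C(NCc1ccncc1)Nc1ccc(S(=O)(=O)c2cccc(Cl)c2)cc1` differs from compound 3 in a single place: 3-chlorophenyl in place of benzyl(methyl)amino on a sulfonyl sulfur. Among the measured compounds shown here, no measured pair shows a change of this kind, so the data give no size for it. The step of a 2.0-fold higher number from compound 3 to compound 4 (0.29 log units; within the scatter) is expected to be small, likely within the scatter or slightly toward weaker activation. Compound 4 is therefore estimated at 45 nM, with a range from 10 nM to 250 nM.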

Compound 4, half-maximal effective concentration: 69 nM
Beside the measured number, compound 4's estimate is 1.5-fold (0.19 log units) below it; low and high end bracket the measured number.
By their numbers in this assay, from the lowest: compound 3; then compound 4; then compound 2. At a limit, above all of these: compound 1.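

In this assay, the change on the sulfonyl sulfur gives a 3.0-fold higher number from compound 3 to compound 4 (0.48 log units; beyond the scatter). The position therefore tolerates the loss of the benzyl(methyl)amino nitrogen at a modest cost, with compound 4 still at 69 nM. Nothing measured here accounts for the size of this step.

Going by these compounds, whether the chlorine contributes to this result stays open, and a plain phenyl or a fluorine in its place would address that. It is also unknown how an amine or a carboxylic acid on the new aromatic ring would read.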